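From a Ring-Bearing Group to Carbamoyl

The compounds below may be only part of what the source reports. "The series", "measured", "known", "first", "only" and "open" are said of these compounds alone.

Values in a functional assay on HCT-116 cells (Homo sapiens) for inhibition, read by colorimetric assay, with a stated time of 3 days; on this read-out higher numbers stand for weaker inhibition and lower numbers for stronger inhibition:
- compound 1 `O=C(CCCCCCCNC(=O)c1cc(=O)c(O)co1)Nc1ccccc1`: > 100000 nM (a limit of the assay, not a number)
- compound 2 `COc1ccc(-c2cnc(NC(=O)CCCCCCNC(=O)C(O)(O)C(F)(F)F)s2)cc1`: 930 nM
- compound 3 `O=C(CCCCCCNC(=O)C(O)(O)C(F)(F)F)Nc1ncc(-c2ccc(Br)cc2)s1`: 2460 nM

Compound 1 stands at the limit of > 100000 nM in this assay, at which 1 of the 3 values shown sits, so it has no exact value to start from, only a limit.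

The next compound to be tested is compound 4 `NC(=O)C(=O)NCCCCCCCC(=O)Nc1ccccc1`. The structural change from compound 1 is a group of 3 heavy atoms (1 carbon, 1 nitrogen, 1 oxygen; no ring) in place of a group of 8 heavy atoms (5 carbon, 3 oxygen; one six-membered aromatic ring with 1 hetero atom), on a carbonyl carbon. Put simply, a carbamoyl group takes the place of a group holding a six-membered aromatic ring, on a carbonyl carbon.

Going by the values given here, only one measured step is available for comparison: a 2.6-fold higher number from compound 2 to compound 3 (0.42 log units; beyond the scatter). That modest step is bromo in place of methoxy on an aromatic carbon, which is a different kind of change. Neither compound 2 nor compound 3 carries the carbamoyl group, so this step gives only a rough sense of scale. The closest guide is therefore compound 1 at > 100000 nM, and compound 4 is expected to remain weak in this assay, at or near that limit.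

The expected change is small, an estimated at least 1.4-fold lower number from compound 1 to compound 4 (0.15 log units; that floor lies within the scatter). The estimated value for compound 4 is 70000 nM, with an expected range from 20000 nM to 150000 nM.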

Compound 4, half-maximal inhibitory concentration: > 100000 nM
Compound 4 was reported as a limit (the forecaster's own chance of this, stated with the estimate: 55%); at least 1.4-fold (0.15 log units) between middle value and limit.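

In this assay, compound 1 and compound 4 are both reported only as limits, not as numbers, so the step between them cannot be read: the limit of > 100000 nM in this assay, at which 2 of the 4 values shown sit.

The compounds shown leave open whether carbamoyl on the carbonyl carbon gives stronger or weaker inhibition than the ring-bearing group it replaces, and by how much.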